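The compounds below may be only part of what the source reports. "The series", "measured", "known", "first", "only" and "open" are said of these compounds alone.

Measured compounds:
- compound 1, `O=C(NCc1ccncc1)Nc1ccc(S(=O)(=O)Nc2ccccc2)cc1`: 410 nM
- compound 2, `CN(Cc1ccccc1)S(=O)(=O)c1ccc(NC(=O)NCc2ccncc2)cc1`: 23 nM
- compound 3, `O=C(NCc1ccncc1)Nc1ccc(S(=O)(=O)c2ccc(Cl)cc2)cc1`: 126 nM

In an assay on isolated protein for activation of Nicotinamide phosphoribosyltransferase (Homo sapiens) (a higher number here means that more compound is needed for the effect, a lower number that less compound is needed), compound 1 gives 410 nM, the highest of the three numbers; its nearest neighbour is compound 3 and its furthest is compound 2. Compound 4, `O=C(NCc1ccncc1)Nc1ccc(S(=O)(=O)c2ccccc2)cc1`, has not been measured. It differs from compound 1 as follows: phenyl in place of anilino on a sulfonyl sulfur.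

Among the measured compounds shown here, two measured steps bear on this change, both leaving the anilino group on the sulfonyl sulfur. The step of a 3.3-fold lower number from compound 1 to compound 3 (0.51 log units; beyond the scatter) puts 4-chlorophenyl in its place, and the step of an 18-fold lower number from compound 1 to compound 2 (1.25 log units; beyond the scatter) puts benzyl(methyl)amino there. Compound 4 is closest to compound 3, sharing the sulfone with an all-carbon aromatic ring but lacking the chlorine; the step of a 5.5-fold higher number from compound 2 to compound 3 (0.74 log units; beyond the scatter) shows that compound 3 does not reach the level of compound 2. A modest lowering is therefore expected for compound 4, close to what compound 3 showed because of a 3.3-fold lower number from compound 1 to compound 3 (0.51 log units; beyond the scatter), giving an expected 2.3-fold lower number from compound 1 to compound 4 (0.36 log units; beyond the scatter). Compound 4 is estimated at 180 nM, within 70 nM to 450 nM.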

Compound 4, half-maximal effective concentration: 85 nM
Estimate against measurement, compound 4: 2.1-fold (0.33 log units) above, within the range that was stated.
By their numbers in this assay, from the lowest: compound 2; then compounds 4 and 3 (each within the scatter of the next); then compound 1.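

In this assay, the step of a 4.8-fold lower number from compound 1 to compound 4 (0.68 log units; beyond the scatter) shows that a plain phenyl on the sulfonyl sulfur is enough for a change beyond the scatter, so the lower number of compound 3 does not depend on its chlorine. Indeed, the step of a 1.5-fold lower number from compound 3 to compound 4 (0.17 log units; within the scatter) leaves the chloro group with no readable effect on this number, whereas the step of a 3.7-fold higher number from compound 2 to compound 4 (0.57 log units; beyond the scatter) shows that benzyl(methyl)amino remains apart from phenyl, beyond the scatter. No measurement here explains why these groups on the sulfonyl sulfur differ.

The compounds shown leave open whether benzylamino, methyl(phenyl)amino or a benzyl group on the sulfonyl sulfur would match benzyl(methyl)amino. They also leave open whether a saturated ring such as cyclohexyl, or a pyridine ring, could stand in place of phenyl.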